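The source may report more compounds than this note shows. Statements on the series, on what has been measured and on what is new or still open speak of the compounds shown alone.

Measured compounds:
Compound 1, `COc1ccccc1/C=C/C(=O)/C=C/c1ccc(OCc2cn(CCCCOc3cc(=O)oc4ccccc34)nn2)c(OC)c1`: 43%
Compound 2, `COc1cc(/C=C/C(=O)/C=C/c2ccco2)ccc1OCc1cn(CCOc2cc(=O)oc3ccccc23)nn1`: 72%

Both were tested in a functional assay on HCT-116 cells (Homo sapiens) for inhibition, read by sulforhodamine B assay, with a stated time of 48 h, tested at 50 uM; a lower number here means less inhibition of growth, a higher number more inhibition of growth at the concentration tested. Among the compounds with values here, compound 1 stands lowest of the two numbers; compound 2 lies higher, and that gap is beyond the usual scatter, so the two values show only that compound 2 inhibits growth more at this concentration. Compound 3, `COc1cc(/C=C/C(=O)/C=C/c2cc(OC)c(OC)c(OC)c2)ccc1OCc1cn(CCCCOc2cc(=O)oc3ccccc23)nn1`, has not been measured. It differs from compound 1 in one place: 3,4,5-trimethoxyphenyl in place of 2-methoxyphenyl on a double-bonded chain carbon bound to a double-bonded chain carbon. Nothing in the measured pair reveals what this change does, so the expectation rests on compound 1 alone and carries wide uncertainty. In this assay the expected change is a number 12 percentage points higher from compound 1 to compound 3 (beyond the scatter), a modest move upward that may not clear the scatter. Compound 3 is therefore estimated at 55%, within a range from 35% to 75%.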

Compound 3, percent growth inhibition at one concentration: 63%
For compound 3 the middle estimate is 8 percentage points below the measured one; low and high end bracket the measured number.
By their numbers in this assay, from the lowest: compound 1; then compounds 3 and 2 (each within the scatter of the next).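

Within the data shown here, the first comparison that changes only one place in this assay puts 3,4,5-trimethoxyphenyl in place of 2-methoxyphenyl on a double-bonded chain carbon bound to a double-bonded chain carbon, and it gives a number 20 percentage points higher from compound 1 to compound 3 (beyond the scatter) as its result. This position therefore affects the read-out: with the rest of compound 1 held fixed, the group with more methoxy substituents goes with more inhibition of growth at the concentration tested. Nothing available explains this rise, so it stands as an observation only.

Which of the methoxy groups on the ring accounts for the step stays open, and so does the outcome of placing a ring bearing an amine or a carboxylic acid at the same carbon. Compound 2 differs from compound 3 in more than one place, so it cannot settle either question.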